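Nitro in Place of Chloro on a Purine Thioether Amide

The compounds below may be only part of what the source reports. "The series", "measured", "known", "first", "only" and "open" are said of these compounds alone.

Measured compounds:
compound 1 `O=C(Nc1cc(Sc2ncn[nH]2)c(O)c2ccccc12)c1ccc([N+](=O)[O-])cc1` — > 100000 nM
compound 2 `O=C(Nc1cc(Sc2ncnc3nc[nH]c23)c(O)c2ccccc12)c1ccc(Cl)cc1` — > 100000 nM

In a functional assay on HCT-116 cells (Homo sapiens) for antiproliferative activity, read by MTT assay, with a stated time of 48 h (on this read-out lower numbers stand for stronger inhibition and higher numbers for weaker inhibition), compound 2 reports only a limit, > 100000 nM. Compound 1 likewise reaches only a limit, > 100000 nM. Compound 2 thus stands where every value shown stands: the limit of > 100000 nM in this assay, at which 2 of the 2 values shown sit. Compound 3 `O=C(Nc1cc(Sc2ncnc3nc[nH]c23)c(O)c2ccccc12)c1ccc([N+](=O)[O-])cc1` differs from compound 2 by nitro in place of chloro on an aromatic carbon. For the measured compounds named here, no measured step joins these two; compound 1, which also carries the nitro group, sits at the same limit. A step of a number no higher from compound 2 to compound 3 (the limit leaves the size open) is expected, none beyond the scatter. Compound 3 is therefore estimated at 100000 nM, between 30000 nM and 300000 nM, most likely again only a limit.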

Compound 3, half-maximal inhibitory concentration: > 100000 nM
Compound 3: no number, only a limit; the forecaster's own chance of this, stated with the estimate: 85%; the middle value sits exactly at the limit.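

In this assay, for the compounds shown here, compound 3 gives > 100000 nM, which is a limit and not a number; no step from compound 1 or compound 2 to compound 3 can be read. The compounds shown leave open what actual potency any of the three has.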